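Acetoxy in Place of Hydrogen on a Cembranolide Core

A few compounds are considered here, and "the series" means these few. Any claim that something is new, unique, unknown or untested is made for them only; others in the source may bear on it.

Compound 1 `C=C1C(=O)O[C@@H]2C/C(C)=C/CC/C(C)=C/CC[C@]3(C)O[C@H]3C[C@@H]12` is a cembranolide bearing an epoxide and an exocyclic methylene lactone. In a functional assay on P388 cells (Mus musculus) for cytotoxicity (a lower number here means that less compound is needed, a higher number that more compound is needed for the effect), compound 1 gives 0.16 ug/mL. For the measured compounds named here, of the two numbers measured, this is the higher one, but the only neighbour, compound 2 `C=C1C(=O)O[C@@H]2[C@H]1[C@H](OC(C)=O)C/C(C)=C/C[C@H](OC(C)=O)/C(C)=C/C[C@@H](OC(C)=O)[C@]1(C)O[C@@H]21`, which carries three acetoxy groups on the same ring system, gives 0.14 ug/mL in this assay, and the two values lie within the scatter of each other, so no order between them can be claimed.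

Compound 3 `C=C1C(=O)O[C@H]2[C@H]1C[C@@H]1O[C@@]1(C)CC/C=C(\C)CC/C=C(\C)[C@@H]2OC(C)=O` is the next member. It differs from compound 1 by acetoxy in place of hydrogen on a saturated ring carbon. Going by the values given here, no step between measured compounds is available to say what such a change does on this core. The pair of compound 1 and compound 2 only shows that a heavily acetylated relative lands in the same range, and nothing more can be drawn from it.

On that basis, the step of a 1.1-fold higher number from compound 1 to compound 3 (0.05 log units; within the scatter) is expected to stay within the scatter, in no particular direction. Compound 3 is therefore estimated to give 0.18 ug/mL in this assay, with a range from 0.06 ug/mL to 0.55 ug/mL.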

Compound 3, concentration for half-maximal effect: 0.38 ug/mL
The estimate for compound 3 lay 2.1-fold (0.32 log units) below the measured number; the measured number falls inside the stated range.
By their numbers in this assay, from the lowest: compounds 2 and 1 (each within the scatter of the next); then compound 3.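

In this assay, for the compounds shown here, acetoxy in place of hydrogen on this saturated ring carbon produces a 2.4-fold higher number from compound 1 to compound 3 (0.38 log units; beyond the scatter), and this is the only step on the shared core that can be read from a change in one place. It shows that this carbon of the 14-membered ring, next to the ring atom that bears a methyl group, is not indifferent to the change: the step is modest, but it lies beyond the scatter and means that more compound is needed for the effect. Nothing at hand explains why acetoxy at this carbon moves the number in this direction.

The compounds shown leave open whether a hydroxyl group or a longer ester such as butyryloxy on the same carbon would move the number in the same direction and by a similar amount. Going by these compounds alone, they also leave open whether the step belongs to this carbon alone, as no step in one place isolates acetoxy on any other ring carbon of the core.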